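A few compounds are considered here, and "the series" means these few. Any claim that something is new, unique, unknown or untested is made for them only; others in the source may bear on it.

Compound 1 `C=CCn1c(=O)/c(=C\c2cccc(F)c2)[nH]c(=O)/c1=C\c1ccccc1OC`: 19700 nM. Compound 2 `C=CCn1c(=O)/c(=C\c2ccccc2Cl)[nH]c(=O)/c1=C\c1ccccc1OC`: 5300 nM. Compound 3 `C=CCn1c(=O)/c(=C\c2ccc(F)c(Br)c2)[nH]c(=O)/c1=C\c1ccccc1OC`: "not active" (no number reported).

All three were tested in a functional assay on A549 cells (Homo sapiens) for cytotoxicity, read by CCK-8 assay, with a stated time of 72 h; a higher number here means a weaker inhibitor, a lower number a stronger inhibitor. Compound 2 gives the lowest of the two numbers reported; its nearest neighbour is compound 1, separated by the step of a 3.7-fold lower number from compound 1 to compound 2 (0.57 log units; beyond the scatter), which is beyond the scatter. Compound 3 gave no number. The new compound 4 `C=CCn1c(=O)/c(=C\c2cc(F)ccc2C)[nH]c(=O)/c1=C\c1ccccc1OC` differs from compound 2 in one place: 5-fluoro-2-methylphenyl in place of 2-chlorophenyl on a double-bonded chain carbon bound to an aromatic carbon. Within the data shown here, the only step that bears on this change is a 3.7-fold lower number from compound 1 to compound 2 (0.57 log units; beyond the scatter), where a ring bearing fluorine gave way to one bearing chlorine with a modest gain. Compound 4 carries both fluorine and methyl, so its number is expected to fall between compounds 1 and 2. The expected step of a 2.3-fold higher number from compound 2 to compound 4 (0.35 log units; beyond the scatter) points toward a higher number. Compound 4 is estimated at 12000 nM, with a range from 4000 nM to 40000 nM.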

Compound 4, half-maximal inhibitory concentration: 4900 nM
Estimate against measurement, compound 4: 2.4-fold (0.39 log units) above; low and high end bracket the measured number.
By their numbers in this assay, from the lowest: compounds 4 and 2 (each within the scatter of the next); then compound 1.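

In this assay the step is a 1.1-fold lower number from compound 2 to compound 4 (0.03 log units; within the scatter) so 5-fluoro-2-methylphenyl and 2-chlorophenyl cannot be told apart at this place on the double-bonded chain carbon. Methyl in place of hydrogen on an aromatic carbon gives a 4.0-fold lower number from compound 1 to compound 4 (0.60 log units; beyond the scatter) and so a fluorinated ring can match the chlorinated one when it also carries methyl. Nothing measured here explains either step.

The compounds shown leave open what a ring bearing methyl alone would give. They also leave open how this ring would fare with an amine or a carboxylic acid on it.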